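Branched-chain series: methyl added to compound 3

A few compounds are considered here, and "the series" means these few. Any claim that something is new, unique, unknown or untested is made for them only; others in the source may bear on it.

Compound 3 `CCCC(C)(C)/N=C(\NC#N)Nc1cccnc1` holds the lowest number of the three measured here. In a functional assay on the whole organism (blood, strain Wistar-Okamoto) with Rattus norvegicus as the target, with a stated time of 5 days (on this read-out lower numbers stand for an effect already at smaller amounts and higher numbers for an effect only at larger amounts of compound), compound 3 gives 1 mg/kg; compound 1 `N#CN/C(=N\C1CCCC1)Nc1cccnc1` gives 20 mg/kg and compound 2 `N#CN/C(=N\C1CCCCC1)Nc1cccnc1` gives 20 mg/kg. The step of no change at the digits printed from compound 1 to compound 2 (within the scatter) shows that exchanging one ring for another on the double-bonded nitrogen leaves the number where it was, whereas a 20-fold lower number from compound 1 to compound 3 (1.30 log units; beyond the scatter) and a 20-fold lower number from compound 2 to compound 3 (1.30 log units; beyond the scatter) show that the branched chain of compound 3 brings a large drop.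

Compound 4 `CC(C)CC(C)(C)/N=C(\NC#N)Nc1cccnc1` differs from compound 3 as follows: methyl in place of hydrogen on a saturated chain carbon bound to two saturated chain carbons. For the measured compounds named here, no measured step adds a single carbon to the chain on the double-bonded nitrogen; the only steps that bear on it are those that reach compound 3, and they concern the change from ring to branched chain, not a lengthening of the chain itself. A small step is therefore expected in this assay, with no clear direction, and most likely one that stays within the scatter, as no change at the digits printed from compound 3 to compound 4 (within the scatter) expresses. For compound 4 the estimate in this assay is 1 mg/kg, with a range from 0.4 mg/kg to 3 mg/kg.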

Compound 4, minimum effective dose: 2.5 mg/kg
Compound 4: middle estimate off by 2.5-fold (0.40 log units), on the low side, and the stated range covers the measured number.
By their numbers in this assay, from the lowest: compound 3; then compound 4; then compounds 1 and 2 (each within the scatter of the next).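

In this assay, methyl in place of hydrogen on a saturated chain carbon bound to two saturated chain carbons gives a 2.5-fold higher number from compound 3 to compound 4 (0.40 log units; beyond the scatter), so this place on the branched chain responds to one added carbon, whereas the ring exchange gave no change at the digits printed from compound 1 to compound 2 (within the scatter). The shift in the propyl to isobutyl change is modest and smaller than the step from ring to branched chain, a 20-fold lower number from compound 1 to compound 3 (1.30 log units; beyond the scatter). No measurement on hand bears on the reason for this shift.

On these data alone, whether ethyl on this carbon would raise the number further, or a hydroxyl group there would move it the other way, remains open. Also open, as far as these compounds go, is whether a methyl on another carbon of the chain would bring a similar shift.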